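Triazine acrylamides on Raji cells: compound 3 to compound 4

This account rests on a few compounds, and the source may have more. Where it says the series, first, only, none or still open, it means among the compounds named here.

Measured so far:
compound 1 `C=CC(=O)Nc1cc(Nc2ncnc(Nc3ccc(C(=O)N4CCCCC4)cc3)n2)ccc1C` — 30600 nM
compound 2 `C=CC(=O)Nc1cccc(Nc2ncnc(Nc3ccc(-c4cccnc4)cc3)n2)c1` — 12400 nM
compound 3 `C=CC(=O)Nc1cccc(Nc2ncnc(Nc3ccc(Oc4ccc(OC)cc4)cc3)n2)c1` — "not determined" (no result reported)

In a functional assay on Raji cells (Homo sapiens) for antiproliferative activity, read by CCK-8 assay, with a stated time of 24 h (on this read-out lower numbers stand for stronger inhibition and higher numbers for weaker inhibition), compound 1 gives 30600 nM, while compound 2 gives 12400 nM. For compound 3 this assay returned "not determined" (no result reported), so compound 3 stands nowhere on the measured scale; only its two relatives anchor the series, both at weak inhibition. Compound 4 `C=CC(=O)Nc1cccc(Nc2ncnc(Nc3ccc(C(=O)Nc4ccc(C)cn4)cc3)n2)c1` differs from compound 3 by (5-methylpyridin-2-yl)carbamoyl in place of 4-methoxyphenoxy on an aromatic carbon. Going by the values given here, no step between measured compounds is available to size this change in this assay, so no direction can be read from the data. Compound 4 is expected near 12000 nM, with a range from 2500 nM to 50000 nM.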

Compound 4, half-maximal inhibitory concentration: 125000 nM
Beside the measured number, compound 4's estimate is 10-fold (1.02 log units) below it; measured number outside the range, above it.
By their numbers in this assay, from the lowest: compound 2; then compound 1; then compound 4.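

In this assay, going by these compounds alone, the change from pyridin-3-yl to (5-methylpyridin-2-yl)carbamoyl on an aromatic carbon gives a 10-fold higher number from compound 2 to compound 4 (1.00 log units; beyond the scatter), the first readable step. This position is therefore not indifferent to its group, and this replacement moves the series toward weaker inhibition, beyond the usual scatter. No measurement on hand accounts for the change.

This single step cannot separate the contribution of the carbamoyl link from that of the methylpyridine ring. As far as these compounds go, how a simple amine or a carboxylic acid at this position would read remains open.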